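Adding a dimethylpyrimidinyl to the sulfonamide of compound 3

The source may report more compounds than this note shows. Statements on the series, on what has been measured and on what is new or still open speak of the compounds shown alone.

Compound 3 `Cc1ccc2oc(=O)c(/C=N/c3ccc(S(N)(=O)=O)cc3)c(Cl)c2c1` gives 360 nM in a functional assay on B16-F10 cells (Mus musculus) for cytotoxicity, read by CCK-8 assay, with a stated time of 48 h (on this read-out lower numbers stand for stronger inhibition and higher numbers for weaker inhibition), the top number of the three, while compound 1 `NS(=O)(=O)c1ccc(/N=C/c2c(Cl)c3ccccc3oc2=O)cc1` gives 300 nM and compound 2 `Cc1ccnc(NS(=O)(=O)c2ccc(/N=C/c3c(Cl)c4cc(C(C)(C)C)cc(C(C)(C)C)c4oc3=O)cc2)n1` gives 190 nM, both within the scatter of compound 3. Among the compounds with values here, the only single-point step, a 1.2-fold higher number from compound 1 to compound 3 (0.08 log units; within the scatter), also lies within the scatter. Compound 4 `Cc1ccc2oc(=O)c(/C=N/c3ccc(S(=O)(=O)Nc4nc(C)cc(C)n4)cc3)c(Cl)c2c1` carries 4,6-dimethylpyrimidin-2-yl in place of hydrogen on a sulfonamide nitrogen. Within the data shown here, no measured step isolates this change; compounds 1 and 2 differ in several places at once, and their two values are within the scatter of each other, so the data give no sign of a shift from this kind of addition. Compound 4 is therefore expected to show a 1.4-fold lower number from compound 3 to compound 4 (0.16 log units; within the scatter), nothing beyond the scatter. The estimate for compound 4 is 250 nM, with a range from 110 nM to 550 nM.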

Compound 4, half-maximal inhibitory concentration: 300 nM
Beside the measured number, compound 4's estimate is 1.2-fold (0.08 log units) below it; the range from low to high includes it.
By their numbers in this assay, from the lowest: compounds 2, 1, 4 and 3 (each within the scatter of the next).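

In this assay, placing 4,6-dimethylpyrimidin-2-yl on the sulfonamide nitrogen gives a 1.2-fold lower number from compound 3 to compound 4 (0.08 log units; within the scatter). Within the data shown here, this is the only step that isolates the change, and it shows that the sulfonamide nitrogen accepts this ring without a shift beyond the scatter. No measurement at hand bears on what lies behind this result.

As far as these compounds go, whether a smaller acetyl group, a carboxylic acid-bearing chain or a pyridine ring on that nitrogen would move the number stays open. So does whether the same addition reads alike on the core of compound 1.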